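This account rests on a few compounds, and the source may have more. Where it says the series, first, only, none or still open, it means among the compounds named here.

Compound 1 `Cc1ccc2ncc(S(=O)(=O)c3cc(F)cc(F)c3)c(N3CCC(C)CC3)c2c1`: 72%
Compound 2 `Cc1cc(C)cc(S(=O)(=O)c2cnc3ccc(Cl)cc3c2N2CCC(C)CC2)c1`: 49%

Of the compounds shown here, two have been measured in an assay on isolated protein for displacement of a labelled ligand from metabotropic glutamate receptor 5 (Homo sapiens), with a stated time of 60 min, tested at 1 uM; a higher number here means more inhibition at the concentration tested (going by the name of the read-out), a lower number less inhibition. In this assay compound 1 gives 72%. Compound 2 gives 49%, the lower of the two numbers, and the gap to compound 1 lies beyond the usual scatter of repeated runs. The two compounds differ from each other in more than one place, so no single change can be credited with that gap.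

The next compound, compound 3 `CC1CCN(c2c(S(=O)(=O)c3cc(F)cc(F)c3)cnc3ccc(Cl)cc23)CC1`, has not yet been measured. It differs from compound 2 in one place: 3,5-difluorophenyl in place of 3,5-dimethylphenyl on a sulfonyl sulfur. The group that enters is the same 3,5-difluorophenyl that compound 1 carries on its sulfonyl sulfur, and compound 1 gives 72% in this assay. Among the measured compounds shown here, the step from compound 2 to compound 3 is therefore expected to be upward, though with a wide spread, since no pair that differs only in this place has been measured. The step expected is a number 15 percentage points higher from compound 2 to compound 3 (beyond the scatter). Compound 3 is estimated to give about 64%, with a range from 45% to 82%.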

Compound 3, a percentage reported as inhibition, at one concentration (the size of the read-out at that concentration, not a potency): 93%
Beside the measured number, compound 3's estimate is 29 percentage points below it; measured number above the stated range.
By their numbers in this assay, from the lowest: compound 2; then compound 1; then compound 3.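

Swapping 3,5-dimethylphenyl for 3,5-difluorophenyl on the sulfonyl sulfur gives a number 44 percentage points higher from compound 2 to compound 3 (beyond the scatter) in this assay, the first pair to isolate this place, and it shows that the choice of group there strongly shifts this read-out even though both groups have 8 heavy atoms. The chloro-bearing aromatic carbon also matters: with 3,5-difluorophenyl held constant, chloro in place of methyl gives a number 21 percentage points higher from compound 1 to compound 3 (beyond the scatter), a modest step that is smaller than the change on the sulfonyl sulfur. Nothing here explains why either change moves the number.

The compounds shown leave open whether plain phenyl, 3,5-dichlorophenyl or 3,5-dimethoxyphenyl on the sulfonyl sulfur would give a number close to that of 3,5-difluorophenyl. They also leave open whether bromo or a nitrile could stand in for chloro on the aromatic carbon, and since each number is a percentage at one concentration, none of them gives a potency.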